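The source may hold more compounds than are shown below. What is called first, only, known or untested is meant among the compounds shown, and "the series" means these compounds.

Series notes, cytotoxicity read-out.

Three compounds are measured in a functional assay on SH-SY5Y cells (Homo sapiens) for cytotoxicity, read by MTT assay, with stated times of 24 h and 4 h; on this read-out lower numbers stand for an effect already at smaller amounts and higher numbers for an effect only at larger amounts of compound. Compound 1 `COc1cc(CNC(=O)/C=C/c2ccccc2)ccc1OCc1nc(C)c(C)nc1C` gives 7310 nM. Compound 2 `COc1cc(CNC(=O)/C=C/c2cccc(OCc3nc(C)c(C)nc3C)c2)ccc1OCc1nc(C)c(C)nc1C` gives 8700 nM. Compound 3 `COc1cc(CNC(=O)/C=C/c2ccc(OCc3nc(C)c(C)nc3C)c(OC)c2)ccc1O` gives 10200 nM, the highest of the three, although its nearest neighbour is compound 2 and its furthest is compound 1, both within the scatter, so no order among the three can be claimed.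

From compound 2 to compound 1 the change is hydrogen in place of (3,5,6-trimethylpyrazin-2-yl)methoxy on an aromatic carbon, and it made a 1.2-fold lower number from compound 2 to compound 1 (0.08 log units; within the scatter), a step within the scatter.

Compound 4 `COc1cccc(/C=C/C(=O)NCc2ccc(O)c(OC)c2)c1` is not yet measured. It differs from compound 3 by hydrogen in place of (3,5,6-trimethylpyrazin-2-yl)methoxy on an aromatic carbon. This is the same kind of change as that from compound 2 to compound 1, but the place is not identical: in compound 2 the leaving group sits meta to a large group, in compound 3 it sits ortho to a methoxy group and para to a large group. How the core of compound 3 differs from that of compound 2 is not broken down here.

Among the measured compounds shown here, for compound 4 in this assay a step of about a 1.2-fold lower number from compound 3 to compound 4 (0.08 log units; within the scatter) is expected, because the measured step of a 1.2-fold lower number from compound 2 to compound 1 (0.08 log units; within the scatter) stayed within the scatter and there is only that one precedent. The estimate for compound 4 is therefore 8500 nM, between 4000 nM and 18000 nM.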

Compound 4, half-maximal effective concentration: 5240 nM
The estimate for compound 4 lay 1.6-fold (0.21 log units) above the measured number; low and high end bracket the measured number.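

In this assay hydrogen in place of (3,5,6-trimethylpyrazin-2-yl)methoxy gave a 1.9-fold lower number from compound 3 to compound 4 (0.29 log units; within the scatter) and the two steps of this exchange can be set side by side: the same change on two cores in this assay, a 1.2-fold lower number (0.08 log units; within the scatter) from compound 2 to compound 1 and a 1.9-fold lower number (0.29 log units; within the scatter) from compound 3 to compound 4, 1.6-fold (0.21 log units) apart, within the scatter of two such steps. On these two cores the exchange therefore carries over with no difference that can be claimed, and neither step separates the compounds it joins. This does not show that the change is without effect or that it would transfer generally: it rests on two pairs, the place differs between them (on compound 3 it is ortho to a methoxy group and para to a large group), and a small real difference could lie within the scatter.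

The compounds shown leave open whether another group at these places, such as an amine, a carboxylic acid or a longer alkoxy chain, would give a step beyond the scatter. They also leave open how the same exchange behaves on any further core.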